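This account rests on a few compounds, and the source may have more. Where it says the series, first, only, none or still open, it means among the compounds named here.

In a functional assay on B16-F10 cells (Mus musculus) (on this read-out higher numbers stand for an effect only at larger amounts of compound and lower numbers for an effect already at smaller amounts), compound 1 `Nc1ncn(C[C@@H]2CO[C@H](CO)O2)c(=O)n1` gives 70000 nM and compound 2 `Nc1ncn(C[C@H]2CO[C@H](CO)O2)c(=O)n1` gives 70000 nM, so compound 2 stands level with compound 1. Compound 3 `Cc1nn(C[C@@H]2CO[C@H](CO)O2)c(=O)[nH]c1=O` reaches only a limit of the assay, > 100000 nM. Compound 4 `Nc1ncn(C[C@@H]2CO[C@@H](CO)O2)c(=O)n1` is the mirror image of compound 2: the two compounds have the same atoms and bonds and differ only in configuration as drawn: 2 of 2 stereo elements differ (all stereocentres are inverted: mirror images); a stereocentre at a saturated ring carbon is drawn S in compound 2 and R in compound 4; a stereocentre at a saturated ring carbon is drawn S in compound 2 and R in compound 4. For the measured compounds named here, one measured step bears on this change, no change at the digits printed from compound 1 to compound 2 (within the scatter), and it concerns (the fact that compounds 1 and 2 differ only in the configuration as drawn), with only one of the two stereocentres differing. Going by the values given here, no measured step shows both stereocentres inverted together, so the evidence is thin. The expected result is no change at the digits printed from compound 2 to compound 4 (within the scatter), with no shift in either direction beyond the scatter in this assay. Compound 4 is estimated at 70000 nM, with an expected range of 25000 nM to 130000 nM.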

Compound 4, half-maximal effective concentration: 80000 nM
Estimate against measurement, compound 4: 1.1-fold (0.06 log units) below; the range from low to high includes it.
By their numbers in this assay, from the lowest: compounds 1, 2 and 4 (each within the scatter of the next). At a limit, above all of these: compound 3.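

Inverting both stereocentres together, a change no earlier pair showed, leaves the numbers in this assay within the scatter (a 1.1-fold higher number from compound 2 to compound 4 (0.06 log units; within the scatter)). Inverting only the other stereocentre, not the one that separates compound 1 from compound 2, reads the same (a 1.1-fold higher number from compound 1 to compound 4 (0.06 log units; within the scatter)). Across compounds 1, 2 and 4, then, neither stereocentre alone nor both together shifts this read-out beyond the scatter. On these data alone, whether that holds once the hydroxymethyl group gives way to a carboxylic acid or a longer chain stays open.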